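A few compounds are considered here, and "the series" means these few. Any claim that something is new, unique, unknown or untested is made for them only; others in the source may bear on it.

Working notes on the series. In a functional assay on U2OS cells for antagonist activity at proto-oncogene Wnt-3 (Homo sapiens), read by a luciferase reporter, with a stated time of 18 h (on this read-out higher numbers stand for an effect only at larger amounts of compound and lower numbers for an effect already at smaller amounts), compound 1 `CCNC(=O)N1CCC[C@H]1C(=O)N1CCC(NS(=O)(=O)c2cc(S(=O)(=O)c3ccccc3)ccc2C(F)(F)F)CC1` gives 90 nM. Compound 2 `CC(C)(C)NC(=O)N1CCC[C@H]1C(=O)N1CCC(NS(=O)(=O)c2cc(S(=O)(=O)c3ccccc3)ccc2C(F)(F)F)CC1`, which carries tert-butyl in place of ethyl on an amide-type nitrogen, gives 30 nM in this assay; the step of a 3.0-fold lower number from compound 1 to compound 2 (0.48 log units; beyond the scatter) is the only measured one and lies beyond the scatter. Compound 2 thus stands at the lower end of the two numbers shown, with compound 1 as its only neighbour.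

Compound 3 `O=C([C@@H]1CCCN1C(=O)Nc1ccccc1)N1CCC(NS(=O)(=O)c2cc(S(=O)(=O)c3ccccc3)ccc2C(F)(F)F)CC1` differs from compound 2 by phenyl in place of tert-butyl on an amide-type nitrogen; the group on the amide-type nitrogen, whose other neighbour is a carbonyl carbon, changes so that (tert-butyl)amino becomes anilino, and (tert-butyl)carbamoyl becomes phenylcarbamoyl. Among the measured compounds shown here, the measured step from ethyl to tert-butyl bears on this place but replaces one alkyl with another; no measured pair shows an aromatic ring here. On this basis no step beyond the scatter is expected, and compound 3 is estimated at 30 nM in this assay, the step of no change at the digits printed from compound 2 to compound 3 (within the scatter) being within the scatter, with a range from 10 nM to 100 nM.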

Compound 3, half-maximal effective concentration: 310 nM
Compound 3: the middle estimate sits 10-fold (1.01 log units) below what was measured, outside the stated range (above it).
By their numbers in this assay, from the lowest: compound 2; then compound 1; then compound 3.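

In this assay, the place on the amide-type nitrogen whose other neighbour is a carbonyl carbon proves sensitive to an aromatic ring: phenyl in place of tert-butyl gives a 10-fold higher number from compound 2 to compound 3 (1.01 log units; beyond the scatter), and phenyl in place of ethyl gives a 3.4-fold higher number from compound 1 to compound 3 (0.54 log units; beyond the scatter), so phenyl gives the highest number of the three groups and both steps lie beyond the scatter. Among the compounds shown here, the earlier pair showed only one direction of change among alkyl groups, whereas the three compounds together show no simple trend with heavy-atom count: the number falls from ethyl to tert-butyl, but compound 3, which carries the group with the most heavy atoms, goes against any reading that more heavy atoms here lower it. Nothing available explains this rise in the number.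

The compounds shown leave open whether the rise belongs to aromatic character or to a ring of any kind, a distinction that a cyclohexyl group on this nitrogen would test. Also open, on these data alone, is whether a benzyl group or a fluorophenyl group would stay close to compound 3 or return towards compound 2.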